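A few compounds are considered here, and "the series" means these few. Any claim that something is new, unique, unknown or untested is made for them only; others in the source may bear on it.

Measured compounds in a functional assay on SW480 cells (Homo sapiens) for antiproliferative activity, read by MTT assay, with a stated time of 72 h; on this read-out higher numbers stand for weaker inhibition and lower numbers for stronger inhibition:
compound 1 `CCOC(=O)c1cc(=O)c2cc(CSC(=S)N(C(C)C)C(C)C)ccc2o1`: > 25000 nM, a limit of the assay.
compound 2 `CCOC(=O)c1cc(=O)c2cc(CSC(=S)N(C)c3ccccc3)ccc2o1`: > 25000 nM, a limit of the assay.
compound 3 `COc1ccc2occ(CSC(=S)N(C(C)C)C(C)C)c(=O)c2c1`: 4800 nM.

Compound 2 stands only at a limit in this assay, as the limit of > 25000 nM in this assay, at which 2 of the 3 values shown sit, records; no number is known for it. Among the compounds with values here, the single measured step touching the amine on the thiocarbonyl carbon, a step that the two limits leave unreadable from compound 1 to compound 2, is unreadable because the limit of > 25000 nM in this assay, at which 2 of the 3 values shown sit, covers both ends. The change to compound 4 `CCOC(=O)c1cc(=O)c2cc(CSC(=S)N3CCCC3)ccc2o1` is pyrrolidin-1-yl in place of methyl(phenyl)amino on a thiocarbonyl carbon. Within the data shown here, compound 3 carries a different core and gives the only numbered value, so it does not fix the size of this step. Compound 4 is expected to stay near the limit, with an estimate of 25000 nM in this assay (range 5000 nM to 100000 nM). The expected step is a number no higher from compound 2 to compound 4 (the limit leaves the size open), which means no readable change is anticipated.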

Compound 4, half-maximal inhibitory concentration: > 25000 nM
Compound 4 gave a limit, no number; the forecaster's own chance of this, stated with the estimate: 70%; the middle value lies on the limit itself.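

In this assay, within the data shown here, compound 4 is also a limit, so no step among compound 1, compound 2 and compound 4 can be read: the limit of > 25000 nM in this assay, at which 3 of the 4 values shown sit.
Going by these compounds, whether the amine on the thiocarbonyl carbon affects the read-out on this shared core remains open.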